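From bromo to methoxy: what compound 4 might show

The source may report more compounds than this note shows. Statements on the series, on what has been measured and on what is new or still open speak of the compounds shown alone.

In a functional assay on A549 cells (Homo sapiens) for antiproliferative activity, read by MTT assay, with a stated time of 48 h (a higher number here means a weaker inhibitor, a lower number a stronger inhibitor), compound 1 (`O=C(/C=C/c1ccc(C(F)(F)F)cc1)Nc1nnc(-c2ccc(Br)cc2)s1`) gives 4.68 ug/mL as its reading. Two close relatives replace its trifluoromethyl group: compound 2 (`O=C(/C=C/c1ccc(F)cc1)Nc1nnc(-c2ccc(Br)cc2)s1`) with fluoro gives 2.83 ug/mL and compound 3 (`Cc1ccc(/C=C/C(=O)Nc2nnc(-c3ccc(Br)cc3)s2)cc1`) with methyl gives 1.51 ug/mL in the same test. Compound 1 therefore sits at the weak end of this small set, clearly apart only from compound 3.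

Compound 4 (`COc1ccc(-c2nnc(NC(=O)/C=C/c3ccc(C(F)(F)F)cc3)s2)cc1`) keeps the trifluoromethyl group but has methoxy in place of bromo on an aromatic carbon. Going by the values given here, no measured step touches the bromo. The data show a 1.7-fold lower number from compound 1 to compound 2 (0.22 log units; within the scatter) and a 1.9-fold lower number from compound 2 to compound 3 (0.27 log units; within the scatter) and a 3.1-fold lower number from compound 1 to compound 3 (0.49 log units; beyond the scatter) but all of these swap a different group, so they only suggest how far one small swap can move the number here. No step beyond the scatter is expected, in either direction. The expected change is a 1.2-fold lower number from compound 1 to compound 4 (0.07 log units; within the scatter) and it is only a rough guess. For compound 4 the estimated value is 4 ug/mL with an expected range from 1.8 ug/mL to 9 ug/mL as its limits.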

Compound 4, half-maximal inhibitory concentration: 0.69 ug/mL
Compound 4: middle estimate off by 5.8-fold (0.76 log units), on the high side, and the stated range ends above it.
By their numbers in this assay, from the lowest: compound 4; then compounds 3, 2 and 1 (each within the scatter of the next, the first and the last beyond it).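

Swapping the 4-bromophenyl group for the 4-methoxyphenyl group gives a 6.8-fold lower number from compound 1 to compound 4 (0.83 log units; beyond the scatter) in this assay, a step beyond the scatter. Going by these compounds alone, this is the first sign that the bromo position matters: the reading responds to a change on this ring, not only to swaps at the trifluoromethyl group. Here one bromine atom leaves and two heavy atoms enter, one of them a hydrogen-bond acceptor, but no measurement in hand explains why the number falls.

As far as these compounds go, compound 2 and compound 3 both carry bromo, so whether methoxy lowers the number in the same way alongside fluoro or methyl remains open. How an amine, a hydroxyl group or a longer chain such as ethoxy would read at this position is also unknown.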